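From Chloro to Carboxy: An Untested Step

The compounds below may be only part of what the source reports. "The series", "measured", "known", "first", "only" and "open" are said of these compounds alone.

In a physicochemical assay, read by spectrophotometry, with a stated time of 10 min (on this read-out lower numbers stand for stronger inhibition and higher numbers for weaker inhibition), compound 1 `Cc1ccc2nc(NCCCCOc3cc(O)c4c(=O)cc(-c5ccccc5)oc4c3)sc2c1` gives 8.79 ug/mL, compound 2 `O=c1cc(-c2ccccc2)oc2cc(OCCCCNc3nc4ccc(Cl)cc4s3)cc(O)c12` gives 4.16 ug/mL and compound 3 `O=c1cc(-c2ccccc2)oc2cc(OCCCCNc3nc4ccc(C(F)(F)F)cc4s3)cc(O)c12` gives 4.95 ug/mL. Compound 2 thus stands within the scatter of compound 3 and clear of compound 1 only. The modest step of a 2.1-fold lower number from compound 1 to compound 2 (0.32 log units; beyond the scatter) lies beyond the scatter, while a 1.8-fold lower number from compound 1 to compound 3 (0.25 log units; within the scatter) and a 1.2-fold higher number from compound 2 to compound 3 (0.08 log units; within the scatter) lie within it.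

Compound 4 `O=C(O)c1ccc2nc(NCCCCOc3cc(O)c4c(=O)cc(-c5ccccc5)oc4c3)sc2c1` has carboxy in place of chloro on an aromatic carbon, turning 6-chloro-1,3-benzothiazol-2-yl into 6-carboxy-1,3-benzothiazol-2-yl. Going by the values given here, no measured compound carries carboxy, so the exchanges among methyl, chloro and trifluoromethyl are the only guide, and all three steps are small. In this assay, a similarly small move toward a higher number is therefore expected, though the direction is uncertain. The expected step is a 1.4-fold higher number from compound 2 to compound 4 (0.16 log units; within the scatter), which would stay within the scatter. Compound 4 is estimated at 6 ug/mL, with an expected range from 2.5 ug/mL to 14 ug/mL.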

Compound 4, half-maximal inhibitory concentration: 6.74 ug/mL
Estimate against measurement, compound 4: 1.1-fold (0.05 log units) below; measured number inside the range.
By their numbers in this assay, from the lowest: compounds 2, 3, 4 and 1 (each within the scatter of the next, the first and the last beyond it).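

In this assay the exchange of groups at this position now reaches carboxy, which brings a hydrogen-bond donor and a hydrogen-bond acceptor that chloro lacks, and a 1.6-fold higher number from compound 2 to compound 4 (0.21 log units; within the scatter) and a 1.4-fold higher number from compound 3 to compound 4 (0.13 log units; within the scatter) and a 1.3-fold lower number from compound 1 to compound 4 (0.12 log units; within the scatter) all lie within the scatter. Going by these compounds alone, the earlier compounds carried neither donor nor acceptor in this group, so compound 4 is the first to show that a group with both, on the 6-position of the 1,3-benzothiazol-2-yl unit, keeps the number in the range of the other three. Nothing measured here accounts for this closeness.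

The compounds shown leave open whether an amine or a methyl ester at this position would also stay this close. They also leave open whether carboxy would read the same way on a longer chain.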